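This account rests on a few compounds, and the source may have more. Where it says the series, first, only, none or still open, it means among the compounds named here.

Three compounds share one core and were all tested in an assay on microsomes from liver for inhibition of sterol O-acyltransferase 1 (Rattus norvegicus); on this read-out higher numbers stand for weaker inhibition and lower numbers for stronger inhibition. Compound 1, with the structure `CCCCCCOc1cc(-c2ccccc2)c(-c2ccccc2)nn1`, gives 72000 nM. Compound 2, with the structure `CCCCCCCOc1cc(-c2ccccc2)c(-c2ccccc2)nn1`, gives 58000 nM. The difference between them is methyl in place of hydrogen on a saturated chain carbon, six bonds along the chain from an oxygen on an aromatic ring, and it made the step of a 1.2-fold lower number from compound 1 to compound 2 (0.09 log units; within the scatter). Compound 3, with the structure `CCCCCCC[S+]([O-])c1cc(-c2ccccc2)c(-c2ccccc2)nn1`, gives 77000 nM; it differs from compound 1 in its core by a group of 9 heavy atoms (7 carbon, 1 oxygen, 1 sulfur; no ring) in place of a group of 7 heavy atoms (6 carbon, 1 oxygen; no ring), on an aromatic carbon. The steps of a 1.1-fold higher number from compound 1 to compound 3 (0.03 log units; within the scatter) and a 1.3-fold higher number from compound 2 to compound 3 (0.12 log units; within the scatter) show that all three numbers sit close together.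

Compound 4, with the structure `CCCCCCCC[S+]([O-])c1cc(-c2ccccc2)c(-c2ccccc2)nn1`, has not yet been measured. It differs from compound 3 by methyl in place of hydrogen on a saturated chain carbon, seven bonds along the chain from a sulfur. Going by the values given here, this is the same kind of change as the one from compound 1 to compound 2, although not the same: in the earlier pair the place was six bonds along the chain from an oxygen on an aromatic ring, whereas here it is seven bonds along the chain from a sulfur.

For compound 4 in this assay the expected step is a 1.2-fold lower number from compound 3 to compound 4 (0.07 log units; within the scatter), of about the same size as the earlier step, because a 1.2-fold lower number from compound 1 to compound 2 (0.09 log units; within the scatter) lay within the scatter when the same kind of change was made on the core of compound 1. Compound 4 is therefore estimated at 65000 nM, with a range from 30000 nM to 140000 nM expected.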

Compound 4, half-maximal inhibitory concentration: 92000 nM
Compound 4: the middle estimate sits 1.4-fold (0.15 log units) below what was measured; the range from low to high includes it.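

Putting methyl in place of hydrogen on the chain of compound 3 gave a 1.2-fold higher number from compound 3 to compound 4 (0.08 log units; within the scatter) in this assay, so this step, like the one on the core of compound 1, cannot be told apart from the ordinary spread of repeated measurements. Going by these compounds alone, although the two steps are printed in opposite directions, this should not be read as a real reversal, and the change carried from one core to the other without a detectable difference: the same change on two cores in this assay, a 1.2-fold lower number (0.09 log units; within the scatter) from compound 1 to compound 2 and a 1.2-fold higher number (0.08 log units; within the scatter) from compound 3 to compound 4, 1.5-fold (0.17 log units) apart, within the scatter of two such steps This shows only that the change made no clear difference on either of these two cores; it does not show a dependable effect of the same size on other cores, and two steps this small cannot reveal whether the oxygen-linked and sulfur-linked chains truly respond alike.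

The compounds shown leave open whether a much longer chain would produce a step beyond the scatter, and whether the pattern would hold further along the series. They also leave open what an amine or a carboxylic acid at the end of the chain would do to the number in this assay.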